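A few compounds are considered here, and "the series" means these few. Any claim that something is new, unique, unknown or untested is made for them only; others in the source may bear on it.

Measured so far:
compound 1, `O=C(CSc1ncccn1)N/N=c1/scc(-c2ccc(Br)cc2)n1-c1ccccc1`, 273 ug/mL
compound 2, `Cc1nnc(SCC(=O)N/N=c2/scc(-c3ccc([N+](=O)[O-])cc3)n2-c2ccccc2)s1`, 177 ug/mL

Both compounds were run in an ADME assay on NIH3T3 cells (Mus musculus) for cytotoxicity, read by MTT assay, with a stated time of 24 h; on this read-out higher numbers stand for weaker inhibition and lower numbers for stronger inhibition. Compound 2 gives 177 ug/mL, and compound 1 gives 273 ug/mL. The gap between the two numbers falls within the usual scatter of repeated measurements of this kind, so neither compound can be set apart from the other on cytotoxicity, and no step between them is shown.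

Compound 3, `COc1ccc(-c2cs/c(=N/NC(=O)CSc3nnc(C)s3)n2-c2ccccc2)cc1`, has not yet been measured in this assay. Its difference from compound 2 is methoxy in place of nitro on an aromatic carbon, while the rest of the structure is kept. Nothing in the measured pair speaks to what this change does: the two measured compounds differ in several places at once and their numbers lie within the scatter of each other.

The expectation for compound 3 is therefore a step from compound 2 of a 1.2-fold higher number from compound 2 to compound 3 (0.09 log units; within the scatter), that is, no change beyond the scatter, with a wide range to either side. Compound 3 is estimated at 220 ug/mL, with a range from 110 ug/mL to 460 ug/mL.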

Compound 3, half-maximal inhibitory concentration: 300 ug/mL
For compound 3 the middle estimate is 1.4-fold (0.13 log units) below the measured one, and the stated range covers the measured number.
By their numbers in this assay, from the lowest: compounds 2, 1 and 3 (each within the scatter of the next).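

The change from 4-nitrophenyl to 4-methoxyphenyl is the only single-place comparison among the compounds shown, and in this assay it gives a 1.7-fold higher number from compound 2 to compound 3 (0.23 log units; within the scatter) with the rest of the structure kept. On an aromatic carbon para to a large group, nitro and methoxy therefore cannot be told apart on this read-out, even though the exchange replaces one group with another of a different atom make-up. No measurement bears on why the two groups read alike, and the data offer no explanation for the result.

Among these compounds, whether any other group at this position, such as an amine or a carboxylic acid, would give a step beyond the scatter remains open, since nitro and methoxy are the only pair compared here. Going by these compounds, the contribution of the remainder of the structure also remains open. Compound 2 and compound 3 share it unchanged, and compound 1 differs from each of them in more than one place.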